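From hydroxy to acetoxy on compound 2

The source may hold more compounds than are shown below. What is called first, only, known or untested is meant among the compounds shown, and "the series" means these compounds.

- compound 1 `Oc1cc(O)cc(CCCCCCC/C=C\CCCCCCCCCc2cc(O)cc(O)c2)c1`: 9.4 ug/mL
- compound 2 `Oc1cc(O)cc(CCCCCCC/C=C\CCCCCCCc2cc(O)cc(O)c2)c1`: 10.2 ug/mL

In a functional assay on A2780 cells (Homo sapiens) for cytotoxicity (on this read-out lower numbers stand for stronger inhibition and higher numbers for weaker inhibition), compound 2 gives 10.2 ug/mL, which is level with compound 1 within the usual scatter. Compound 3 `CC(=O)Oc1cc(O)cc(CCCCCCC/C=C\CCCCCCCc2cc(O)cc(O)c2)c1` differs from compound 2 by acetyl in place of hydrogen on an oxygen on an aromatic ring, turning one hydroxy into acetoxy. Within the data shown here, the only measured step, a 1.1-fold higher number from compound 1 to compound 2 (0.04 log units; within the scatter), alters the chain and leaves the hydroxy groups untouched, so it says little about this change. Among the measured compounds shown here, with no measured step on acetylation, no shift beyond the scatter is assumed, and the expected step is a 1.0-fold lower number from compound 2 to compound 3 (0.01 log units; within the scatter). For compound 3, the estimated value is 10 ug/mL, with an expected range of 4.5 ug/mL to 22 ug/mL.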

Compound 3, half-maximal inhibitory concentration: 10.2 ug/mL
Beside the measured number, compound 3's estimate is 1.0-fold (0.01 log units) below it, within the range that was stated.
By their numbers in this assay, from the lowest: compounds 1, 2 and 3 (each within the scatter of the next).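

In this assay, among these compounds, putting acetyl on this oxygen gives no change at the digits printed from compound 2 to compound 3 (within the scatter), the first measured change at a hydroxy group, and turning hydroxy into acetoxy here leaves the number level. Changing the chain end as well, with 3-acetoxy-5-hydroxyphenyl in place of 2-(3,5-dihydroxyphenyl)ethyl, gives a 1.1-fold higher number from compound 1 to compound 3 (0.04 log units; within the scatter), so this series stays level across both kinds of change. No available measurement bears on why the numbers stay level.

Going by these compounds, whether acetyl on the other hydroxy groups would behave the same remains open. So does the effect of a methyl ether or an amine at this position.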